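Series notes: saturated-ring aryl swap at the core of compound 1

The source may report more compounds than this note shows. Statements on the series, on what has been measured and on what is new or still open speak of the compounds shown alone.

Measured so far:
compound 1 `Cn1c(CN2CCC(c3ccccn3)CC2)nc2ccccc21`: > 15800 nM
compound 2 `Cn1c(CN2CCN(c3ccccc3F)CC2)nc2ccccc21`: 6310 nM
compound 3 `Cn1c(CN2CCN(c3ccc(C(F)(F)F)cc3)CC2)nc2ccccc21`: 6310 nM

Compound 1 stands at the edge of what the numbers show. In a functional assay on CHO cells for agonist activity at metabotropic glutamate receptor 2 (Homo sapiens), read by FLIPR (a higher number here means that more compound is needed for the effect, a lower number that less compound is needed), compound 1 gives > 15800 nM, and this is a limit of the assay, not a number; the set contains (the limit of > 15800 nM in this assay, at which 1 of the 3 values shown sits). Compound 2 gives 6310 nM in this assay, and compound 3 gives 6310 nM; these two values sit within the scatter of each other, so nothing separates them. Neither pairs with compound 1 in a single-point step, so from them only the values themselves can be taken.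

Compound 4 `Cn1c(CN2CCC(c3ccccc3F)CC2)nc2ccccc21` is not yet measured. Its change from compound 1 is 2-fluorophenyl in place of pyridin-2-yl on a saturated ring carbon, in words 2-fluorophenyl in place of pyridin-2-yl on a saturated ring carbon. Within the data shown here, no measured step describes this change, and the starting point is a limit, so the direction of the step can only be guessed. The step from compound 1 to compound 4 is expected to be an at least 1.3-fold lower number from compound 1 to compound 4 (0.11 log units; that floor lies within the scatter), with a real chance that the assay again returns only a limit. For compound 4 the expected value in this assay is 12000 nM, between 3000 nM and 40000 nM.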

Compound 4, half-maximal effective concentration: 3980 nM
Compound 4: the middle estimate sits 3.0-fold (0.48 log units) above what was measured; measured number inside the range.
By their numbers in this assay, from the lowest: compounds 4, 2 and 3 (each within the scatter of the next). At a limit, above all of these: compound 1.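

In this assay, among these compounds, 2-fluorophenyl in place of pyridin-2-yl on a saturated ring carbon gives an at least 3.9-fold lower number from compound 1 to compound 4 (0.59 log units; beyond the scatter) and is the first readable step, so the aromatic ring at this place, three ring bonds from the ring nitrogen, does bear on the read-out. For compound 1 the reading of > 15800 nM is a limit of the assay and not a number. The step therefore gives only a floor for the size of this change and not its full size, because its starting point is such a limit: the limit of > 15800 nM in this assay, at which 1 of the 4 values shown sits.

In this change the ring nitrogen leaves and the fluorine enters together, and the compounds shown do not separate the two contributions; an unsubstituted phenyl on the same ring carbon would be needed to tell them apart. Also open, from the compounds shown here alone, is how other groups on that phenyl ring, such as a methoxy group or a nitrile, would read in this assay on this saturated ring carbon.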